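The source may hold more compounds than are shown below. What is called first, only, known or untested is meant among the compounds shown, and "the series" means these compounds.

Measured so far in a toxicity assay on NIH3T3 cells (Mus musculus) for cytotoxicity, read by resazurin assay; on this read-out lower numbers stand for an effect already at smaller amounts and higher numbers for an effect only at larger amounts of compound:
- Compound 1 `CN(C)c1ccc(NCc2cncn2Cc2ccc(-c3ccccc3)cc2)cc1-c1ccccc1`: > 1000 nM, a limit of the assay and not a number
- Compound 2 `c1ccc(-c2ccc(Cn3cncc3CNc3cccc(-c4ccccc4)c3)cc2)cc1`: 10000 nM

Among the measured compounds shown here, compound 2 holds the only actual number in this assay, at 10000 nM. Compound 1 sits at the limit of > 1000 nM in this assay, at which 1 of the 2 values shown sits, so it offers no number to rank compound 2 against.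

The next compound, compound 3 `N#Cc1ccc(NCc2cncn2Cc2ccc(-c3ccccc3)cc2)cc1-c1ccccc1`, takes compound 2 and makes a single change: cyano in place of hydrogen on an aromatic carbon.

For the measured compounds named here, only one measured step bears on this change, and it too concerns a group on an aromatic carbon: a step that the limit leaves unreadable from compound 1 to compound 2. Its size cannot be read, so it lends no measured size to the new step, and it suggests no direction either. With nothing pointing up or down, no step beyond the usual scatter is expected in this assay. The expected change is a 1.4-fold lower number from compound 2 to compound 3 (0.15 log units; within the scatter). The estimate for compound 3 is 7000 nM, with an expected range from 2000 nM to 25000 nM.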

Compound 3, half-maximal effective concentration: > 1000 nM
Compound 3: no number, only a limit; the forecaster's own chance of this, stated with the estimate: 45%; the middle value lies beyond the limit too.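

In this assay compound 3 gives > 1000 nM, a limit of the assay and not a number. Neither the step from compound 2 to compound 3 nor the step from compound 1 to compound 3 can be read. The compounds shown leave open how far, and in which direction, cyano in place of hydrogen or of dimethylamino on an aromatic carbon shifts the number in this assay.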